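Aryl urea series: cytotoxicity read-out across the para substituent

This account rests on a few compounds, and the source may have more. Where it says the series, first, only, none or still open, it means among the compounds named here.

The shared core of compound 1 `COc1ccc(NC(=O)Nc2cc(C)nc3ccccc23)cc1` carries a urea linking a quinoline to a phenyl ring; compound 2 `Cc1cc(NC(=O)Nc2ccc(F)cc2)c2ccccc2n1` and compound 3 `Cc1cc(NC(=O)Nc2ccc(N(C)C)cc2)c2ccccc2n1` vary only the group on that phenyl ring. In an ADME assay on HepG2 cells (Homo sapiens) for cytotoxicity, with a stated time of 72 h (on this read-out higher numbers stand for an effect only at larger amounts of compound and lower numbers for an effect already at smaller amounts), compound 1 gives > 25000 nM, which is a limit of the assay and not a number. In this assay compound 2 gives > 25000 nM, again a limit. In this assay compound 3 gives > 25000 nM, also a limit. Compound 3 therefore stands where the other two stand: at the limit, with no number of its own; all three values sit on the same line (the limit of > 25000 nM in this assay, at which 3 of the 3 values shown sit).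

The move to compound 4 `Cc1cc(NC(=O)Nc2ccc(OC(F)(F)F)cc2)c2ccccc2n1` is trifluoromethoxy in place of dimethylamino on an aromatic carbon. Among the compounds with values here, the steps that bear on this position are the change from compound 2 to compound 3 a step that the two limits leave unreadable from compound 2 to compound 3 and from compound 1 to compound 3 a step that the two limits leave unreadable from compound 1 to compound 3; the step from compound 1 to compound 2 a step that the two limits leave unreadable from compound 1 to compound 2 is likewise unreadable. None of the three gives a size, so no step beyond the scatter can be read from them in either direction.

On this basis compound 4 is expected to show a step that the limit leaves unreadable from compound 3 to compound 4 that again leaves the read-out at the limit. The estimate for compound 4 in this assay is 30000 nM, with a range from 12000 nM to 60000 nM.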

Compound 4, half-maximal effective concentration: 15000 nM
Estimate against measurement, compound 4: 2.0-fold (0.30 log units) above; the measured number falls inside the stated range.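

Trifluoromethoxy is the only group of the four on this aromatic carbon that gives this assay a read-out with a number of its own, and the change from dimethylamino is an at least 1.6-fold lower number from compound 3 to compound 4 (0.22 log units; that floor lies within the scatter). The comparison with the fluoro group gives an at least 1.6-fold lower number from compound 2 to compound 4 (0.22 log units; that floor lies within the scatter), and the comparison with the methoxy oxygen substituent, where trifluoromethyl replaces methyl, gives an at least 1.6-fold lower number from compound 1 to compound 4 (0.22 log units; that floor lies within the scatter). All three steps are floors within the scatter, so the position is now shown to admit a measurable value, but no real drop of established size is shown, and the other three compounds remain at one shared limit: the limit of > 25000 nM in this assay, at which 3 of the 4 values shown sit.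

From the compounds shown here alone, it remains open how far compound 1, compound 2 and compound 3 lie past that limit, and with it the true size of their steps to compound 4. Also open, going by these compounds, is whether a measurable read-out at this position belongs to trifluoromethoxy alone or would recur with a carboxylic acid, a primary amine or a longer alkoxy chain on the same carbon.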